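The source may hold more compounds than are shown below. What is called first, only, known or untested is meant among the compounds shown, and "the series" means these compounds.

Measured in a functional assay on A-375 cells (Homo sapiens) for antiproliferative activity, read by MTT assay, with a stated time of 24 h; on this read-out higher numbers stand for weaker inhibition and lower numbers for stronger inhibition:
- Compound 1 `C#CCOc1ccc2c(=O)c(-c3cc(OC)c(OC)cc3OC)coc2c1`: 3680 nM
- Compound 2 `COc1cc(OC)c(-c2coc3cc(OCc4ccc([N+](=O)[O-])cc4)ccc3c2=O)cc1OC`: > 10000 nM

Compound 2 gives only a limit, > 10000 nM; this is the limit of > 10000 nM in this assay, at which 1 of the 2 values shown sits. Compound 3 `COc1cc(OC)c(-c2coc3cc(OCc4cccc(Br)c4)ccc3c2=O)cc1OC` carries 3-bromophenyl in place of 4-nitrophenyl on a saturated chain carbon bound to an oxygen on an aromatic ring. Within the data shown here, the one measured step at this place is an at least 2.7-fold higher number from compound 1 to compound 2 (0.43 log units; beyond the scatter), beyond the scatter and open-ended. It involves ethynyl, so it bears only loosely on this change. In this assay the expected change is small, toward a lower number: an at least 1.2-fold lower number from compound 2 to compound 3 (0.09 log units; that floor lies within the scatter). For compound 3 the estimated value is 8000 nM, with an expected range of 3000 nM to 20000 nM.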

Compound 3, half-maximal inhibitory concentration: 1120 nM
Estimate against measurement, compound 3: 7.1-fold (0.85 log units) above, and the stated range ends above it.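

At this saturated chain carbon bound to an oxygen on an aromatic ring, a phenyl ring does not by itself cost activity in this assay: 3-bromophenyl in place of ethynyl gives a 3.3-fold lower number from compound 1 to compound 3 (0.52 log units; beyond the scatter). The ring's substituent matters, as 3-bromophenyl in place of 4-nitrophenyl gives an at least 8.9-fold lower number from compound 2 to compound 3 (0.95 log units; beyond the scatter). That step is only a floor, since one end of it is a limit: the limit of > 10000 nM in this assay, at which 1 of the 3 values shown sits.

Still open, going by these compounds, is whether the bromine itself or its place on the ring carries the difference. 4-Bromophenyl and 3-nitrophenyl at this position would separate the two.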